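From a nitrile to a methylindole on a shared core

This account rests on a few compounds, and the source may have more. Where it says the series, first, only, none or still open, it means among the compounds named here.

Measured compounds in a functional assay on A549 cells (Homo sapiens) for inhibition, read by CCK-8 assay, with a stated time of 48 h; on this read-out lower numbers stand for stronger inhibition and higher numbers for weaker inhibition:
compound 1 `COc1cc(-c2cc3nccc(-c4cc(OC)c(OC)c(OC)c4)n3n2)cc(OC)c1OC`: > 10000 nM
compound 2 `COc1cc(-c2ccnc3cc(-c4cn(CO)c5ccccc45)nn23)cc(OC)c1OC`: 167 nM
compound 3 `COc1cc(-c2ccnc3cc(-c4cccc(C#N)c4)nn23)cc(OC)c1OC`: > 10000 nM

Compound 3, the starting point of this account, gives in this assay only a limit, > 10000 nM, and not a number. Compound 1 likewise returns only a limit, > 10000 nM. Two of the three values therefore sit at the limit of > 10000 nM in this assay, at which 2 of the 3 values shown sit, and compound 3 stands among them, with no number of its own to compare. Going by the values given here, compound 2 is the single measured compound that gives a number, 167 nM, and it is also the one that carries an indole group on the shared core in place of the 3-cyanophenyl of compound 3.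

Compound 4 `COc1cc(-c2ccnc3cc(-c4ccc5ccn(C)c5c4)nn23)cc(OC)c1OC` differs from compound 3 in one place: 1-methyl-1H-indol-6-yl in place of 3-cyanophenyl on an aromatic carbon. Among the compounds with values here, no measured pair shows this change directly. Within the data shown here, since the only number among the three measured compounds belongs to compound 2, which also bears an indole, a step toward stronger inhibition beyond the usual scatter is expected for compound 4, an at least 16-fold lower number from compound 3 to compound 4 (1.22 log units; beyond the scatter). Compound 4 is estimated to give 600 nM in this assay, with a range from 100 nM to 5000 nM, while a return of only a limit remains possible.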

Compound 4, half-maximal inhibitory concentration: 829 nM
Beside the measured number, compound 4's estimate is 1.4-fold (0.14 log units) below it, and the stated range covers the measured number.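

In this assay, placing 1-methyl-1H-indol-6-yl instead of 3-cyanophenyl on this aromatic carbon, next to the ring nitrogen, gives an at least 12-fold lower number from compound 3 to compound 4 (1.08 log units; beyond the scatter). Until now only compound 2 had given a number on the shared core, so compound 4 adds a second compound with a measured value and shows directly that this single change at this position can take the read-out from a limit to a number. The real size of the step remains unknown, and the printed figure is only a bound, because one end of it is a limit: the limit of > 10000 nM in this assay, at which 2 of the 4 values shown sit.

The compounds shown leave open whether the step comes from the added five-membered aromatic ring, from the methyl group on the indole nitrogen, or simply from the loss of the nitrile. From the compounds shown here alone, how a plain phenyl, or an indole carrying an amine or a carboxylic acid, would read at this position also remains open.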